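Swapping chloro for an ethylpiperazinylmethyl group

This account rests on a few compounds, and the source may have more. Where it says the series, first, only, none or still open, it means among the compounds named here.

Measured so far in an ADME assay on a cell-free system (plasma, Homo sapiens) for protein binding
Compound 1 `CNc1nccc(N2CC[C@H](NC(=O)Nc3ccc(Cl)c(C(F)(F)F)c3)C2)n1` gives 99.8%
Compound 2 `Nc1nccc(N2CC[C@H](NC(=O)Nc3ccc(Cl)c(C(F)(F)F)c3)C2)n1` gives 99.5%

Compound 1 has the lower unbound fraction of the two measured compounds. Among the compounds with values here, its nearest neighbour is compound 2, and the only measured step is a 2.5-fold higher unbound fraction from compound 1 to compound 2 (0.40 log units; beyond the scatter) for hydrogen in place of methyl on a nitrogen on an aromatic ring. Compound 3 `CCN1CCN(Cc2ccc(NC(=O)N[C@H]3CCN(c4ccnc(NC)n4)C3)cc2C(F)(F)F)CC1` keeps that methyl and instead has (4-ethylpiperazin-1-yl)methyl in place of chloro on an aromatic carbon within the core of compound 1. Within the data shown here, no measured step covers this change, so a 2.5-fold higher unbound fraction from compound 1 to compound 2 (0.40 log units; beyond the scatter) offers only a rough sense of scale. A larger step towards a higher unbound fraction is expected in this assay as a matter of judgement, with wide uncertainty. The expected step on this estimate is a 10-fold higher unbound fraction from compound 1 to compound 3 (1.00 log units; beyond the scatter) overall. For compound 3 the expected value is 98% with an estimated range of 94% to 99.6% in this measurement.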

Compound 3, plasma protein binding: 75.2%
The estimate for compound 3 lay 12-fold (1.09 log units) (unbound fraction) below the measured number; measured number below the stated range.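

In this assay, within the data shown here, the aromatic carbon ortho to a trifluoromethyl group proves far more responsive than the nitrogen substituent varied earlier: (4-ethylpiperazin-1-yl)methyl in place of chloro gives a 120-fold higher unbound fraction from compound 1 to compound 3 (2.09 log units; beyond the scatter), whereas the only earlier change gave a 2.5-fold higher unbound fraction from compound 1 to compound 2 (0.40 log units; beyond the scatter). With this single replacement, compound 3 reaches 75.2%, and the position therefore tolerates a group of 9 heavy atoms, with a six-membered non-aromatic ring, in place of a single chlorine while the value moves well away from that of compound 1. Nothing available accounts for the size of this step.

The compounds shown leave open which part of the entering group carries the step, since the ring, its two nitrogens and the ethyl group arrive together; a dimethylaminomethyl or morpholinylmethyl group at this carbon would help separate them. Also open, going by these compounds, is how the same replacement behaves on compound 2, with hydrogen in place of the methyl.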